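This account rests on a few compounds, and the source may have more. Where it says the series, first, only, none or still open, it means among the compounds named here.

Measured so far in a functional assay on MCF7 cells (Homo sapiens) for inhibition, read by sulforhodamine B assay; a lower number here means a stronger inhibitor of growth, a higher number a weaker inhibitor of growth:
- compound 1 `Cc1ccc2[nH]c(-c3ccc(-c4ccc(-c5cccc(Cl)c5)cc4)cc3)nc2c1` gives 1210 nM
- compound 2 `Clc1cccc(-c2ccc(-c3ccc(-c4nc5ccccc5[nH]4)cc3)cc2)c1` gives 36300 nM

Compound 1 has the lower number of the two. Among the measured compounds shown here, the only measured step (a 30-fold higher number from compound 1 to compound 2 (1.48 log units; beyond the scatter)) is large and comes with hydrogen in place of methyl on an aromatic carbon.

Compound 3 `Cc1ccc2[nH]c(-c3ccc(-c4ccc(-c5ccc(F)cc5)cc4)cc3)nc2c1` keeps that methyl and carries 4-fluorophenyl in place of 3-chlorophenyl on an aromatic carbon, para to a large group (4-fluorophenyl in place of 3-chlorophenyl on an aromatic carbon). The measured step concerns a different place, so it gives no size for this change. For the measured compounds named here, no measured pair shows a change at this place. No step beyond the scatter is therefore expected in this assay, and no direction can be argued from the data.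

Going by the values given here, the expectation rests on compound 1 (1210 nM) as the only measured compound with the methyl, which leaves a wide range. The estimate amounts to an expected small step (a 1.2-fold higher number from compound 1 to compound 3 (0.09 log units; within the scatter)). Compound 3 is expected at about 1500 nM with an estimated range from 500 nM to 4500 nM in repeat measurements.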

Compound 3, concentration for 50% growth inhibition: 30200 nM
Compound 3: the middle estimate sits 20-fold (1.30 log units) below what was measured; measured number above the stated range.
By their numbers in this assay, from the lowest: compound 1; then compounds 3 and 2 (each within the scatter of the next).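

In this assay, 4-fluorophenyl in place of 3-chlorophenyl comes with a 25-fold higher number from compound 1 to compound 3 (1.40 log units; beyond the scatter), the first size measured at this place. With a 30-fold higher number from compound 1 to compound 2 (1.48 log units; beyond the scatter) also large, keeping the methyl is not enough to hold the lower number: among the compounds shown, only compound 1 carries both the methyl and 3-chlorophenyl, and each single change away from it gives a step beyond the scatter. This exchange alters both the halogen and where it sits on the phenyl ring, the pair cannot separate the two, and nothing on hand speaks to why the number rises.

Still open, as far as these compounds go, is whether 3-fluorophenyl or 4-chlorophenyl, with the methyl kept, would read closer to compound 1 or to compound 3, which would show whether the halogen or its location goes with the step. Also open, from the compounds shown here alone, are how an unsubstituted phenyl or a phenyl bearing an amine or a carboxylic acid would read at this place, and whether an ethyl or a methoxy group could stand in for the methyl on the core of compound 1.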